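A tert-Butyl Addition to a Compound at the Assay Limit

This account rests on a few compounds, and the source may have more. Where it says the series, first, only, none or still open, it means among the compounds named here.

Compound 1 `O=c1c(O)c(O)oc2ccc(Cl)cc12`: in a functional assay for inhibition, with Homo sapiens as the target (a lower number here means a stronger inhibitor, a higher number a weaker inhibitor), compound 1 gives 1400000 nM.
Compound 2 `O=c1c(O)c(O)oc2ccc(O)cc12`: in this assay compound 2 gives only a limit, > 4000000 nM.

Compound 2 therefore stands at the limit of this assay, with no number of its own (the limit of > 4000000 nM in this assay, at which 1 of the 2 values shown sits). Within the data shown here, the only measured step, an at least 2.8-fold higher number from compound 1 to compound 2 (0.45 log units; beyond the scatter), is beyond the scatter. Compound 3 `CC(C)(C)c1cc2oc(O)c(O)c(=O)c2cc1O` differs from compound 2 by tert-butyl in place of hydrogen on an aromatic carbon. Among the measured compounds shown here, no measured step exchanges hydrogen for tert-butyl, so that single step gives no guide to this change. Compound 3 is expected to show no step beyond the scatter, a number no higher from compound 2 to compound 3 (the limit leaves the size open), and most likely to stay at the limit. Compound 3 is estimated at 4000000 nM, between 1500000 nM and 10000000 nM.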

Compound 3, half-maximal inhibitory concentration: > 4000000 nM
Compound 3: only a limit was reported; the forecaster's own chance of this, stated with the estimate: 70%; the middle value sits exactly at the limit.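

Compound 2 and compound 3 both give only a limit in this assay, so no step can be read between them. The compounds shown leave open whether tert-butyl in place of hydrogen shifts inhibition at all.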